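The compounds below may be only part of what the source reports. "The series", "measured", "known", "first", "only" and "open" are said of these compounds alone.

Measured so far:

Compound 1, `COc1ccc(CNC(=O)/C(C#N)=C/c2ccco2)cc1`, in a functional assay on BE(2)-C cells (Homo sapiens) for inhibition, read by MTT assay, with a stated time of 72 h (a higher number here means a weaker inhibitor of growth, a lower number a stronger inhibitor of growth), gives 24000 nM.
Compound 2, `COc1ccc(CNC(=O)/C(C#N)=C/c2ccc(Cl)o2)cc1`, in this assay gives 11000 nM.
Compound 3, `N#C/C(=C\c1ccccc1)C(=O)NCc1ccc(Cl)c(Cl)c1`, in this assay gives 32000 nM.

Compound 1 and compound 2 share a core and differ in one place: chloro in place of hydrogen on an aromatic carbon. That single change made a 2.2-fold lower number from compound 1 to compound 2 (0.34 log units; beyond the scatter).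

Compound 3 carries a different core from compound 1; the difference between the two cores is not broken down here. Its number in this assay sits close to that of compound 1, the two lying within the usual scatter of each other, while compound 2 stands further off.

Compound 4, `N#C/C(=C\c1ccc(Cl)cc1)C(=O)NCc1ccc(Cl)c(Cl)c1`, has not yet been measured. It differs from compound 3 in one place: chloro in place of hydrogen on an aromatic carbon. This is the same kind of change as that from compound 1 to compound 2, but not the same: there the chloro entered a five-membered aromatic ring with one oxygen, next to the ring oxygen and two ring bonds from the ring atom that bears a large group; here it enters a six-membered aromatic ring of carbon only, para to a large group.

For the measured compounds named here, on the strength of the only comparable step, a 2.2-fold lower number from compound 1 to compound 2 (0.34 log units; beyond the scatter), a step of similar modest size is expected from compound 3 to compound 4, a 1.8-fold lower number from compound 3 to compound 4 (0.25 log units; within the scatter), with wider uncertainty since the ring and the surroundings of the place differ. Compound 4 is therefore estimated at 18000 nM in this assay, likely between 8000 nM and 40000 nM.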

Compound 4, concentration for 50% growth inhibition: 31000 nM
Compound 4: the middle estimate sits 1.7-fold (0.24 log units) below what was measured; low and high end bracket the measured number.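

Chloro in place of hydrogen on the six-membered aromatic ring, the change from phenyl to 4-chlorophenyl, gives a 1.0-fold lower number from compound 3 to compound 4 (0.01 log units; within the scatter) in this assay, whereas the same kind of change on the core of compound 1 gave a step beyond the scatter. Set side by side, however, the two steps do not differ by more than the scatter allows: the same change on two cores in this assay, a 2.2-fold lower number (0.34 log units; beyond the scatter) from compound 1 to compound 2 and a 1.0-fold lower number (0.01 log units; within the scatter) from compound 3 to compound 4, 2.1-fold (0.33 log units) apart, within the scatter of two such steps. So the data neither show that the modest gain seen with compound 2 carries over to the second core nor show that it fails to, since with only one pair on each core, and the chloro entering a different kind of ring each time, one small shared effect cannot be told apart from an effect on one core alone.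

The compounds shown leave open what another group at the same place would do, such as a bromo, a hydroxyl or an amine. They also leave open what chloro does on the five-membered aromatic ring with one oxygen when the rest of the molecule is that of compound 3, a comparison that would separate the role of the ring from that of the rest of the core.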